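A 3,5-dihydroxyphenyl swap with no number to start from

The compounds below may be only part of what the source reports. "The series", "measured", "known", "first", "only" and "open" are said of these compounds alone.

Measured in a functional assay on G-361 cells (Homo sapiens) for antiproliferative activity, with a stated time of 72 h; a higher number here means a weaker inhibitor, a lower number a stronger inhibitor:
- compound 1 `OC[C@H]1O[C@@H](n2cnc3c(NCc4ccc(Br)cc4)ncnc32)[C@H](O)[C@@H]1O`: > 166000 nM, a limit
- compound 2 `COc1ccccc1CNc1ncnc2c1ncn2[C@@H]1O[C@H](CO)[C@@H](O)[C@H]1O`: > 166000 nM, a limit
- compound 3 `COc1cc(CNc2ncnc3c2ncn3[C@@H]2O[C@H](CO)[C@@H](O)[C@H]2O)cc(OC)c1`: "not determined" (no result reported)

Compound 3 has no number of its own, so it offers no fixed point from which to measure. The only context around it is the limit of > 166000 nM in this assay, at which 2 of the 3 values shown sit. Neither of those two values is a number, and neither places compound 3 on the scale.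

Compound 4 `OC[C@H]1O[C@@H](n2cnc3c(NCc4cc(O)cc(O)c4)ncnc32)[C@H](O)[C@@H]1O` differs from compound 3 in one place: 3,5-dihydroxyphenyl in place of 3,5-dimethoxyphenyl on a saturated chain carbon bound to a nitrogen on an aromatic ring. The 3,5-dihydroxyphenyl group stands in place of 3,5-dimethoxyphenyl on a saturated chain carbon bound to a nitrogen on an aromatic ring.

One measured step changes a group at this same place: a step that the two limits leave unreadable from compound 1 to compound 2. It puts 2-methoxyphenyl in place of 4-bromophenyl, and it yields neither a size nor a direction to carry over. Within the data shown here, no step of known size is therefore expected in this assay, in either direction. Among the measured compounds shown here, the expectation is only that compound 4 stays near the limit reached by its two measured relatives, and this assay may well report a limit again. For compound 4 the estimated value is 130000 nM, with an expected range from 25000 nM to 300000 nM.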

Compound 4, half-maximal inhibitory concentration: > 166000 nM
Compound 4: no number, only a limit (the forecaster's own chance of this, stated with the estimate: 65%); middle value at least 1.2-fold (0.10 log units) away from the limit.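

In this assay compound 4 gives > 166000 nM, which is a limit and not a number. Set beside compound 1 and compound 2, it yields no step that can be read. The compounds shown leave open whether any group at this place on the shared core would give a readable value in this assay, as the results stop at one point: the limit of > 166000 nM in this assay, at which 3 of the 4 values shown sit.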